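The compounds below may be only part of what the source reports. "The series", "measured", "known", "first", "only" and "open" are said of these compounds alone.

Among the compounds with values here, compound 2 `CN(C)CCNc1ccnc2cc(OCc3ccccc3)ccc12` shows the lower of the two numbers available so far in a functional assay on NCI-H1650 cells (Homo sapiens) for cytotoxicity, read by MTT assay, with a stated time of 48 h; on this read-out lower numbers stand for stronger inhibition and higher numbers for weaker inhibition: in this assay compound 2 gives 1620 nM, while compound 1 `CC(C)COc1ccc2c(Cl)ccnc2c1` gives 2100 nM, and the two values sit within the scatter of each other, so no order between them can be claimed. Compound 3 `Clc1ccnc2cc(OCc3ccccc3)ccc12` is not yet measured. It differs from compound 2 in one place: chloro in place of (2-(dimethylamino)ethyl)amino on an aromatic carbon. Within the data shown here, no step between measured compounds corresponds to this change, so the expectation rests only on the two values shown. Compound 1 carries the same chloro group and reaches 2100 nM, which suggests the change need not move the number far. Compound 3 is therefore expected to land close to compound 2, with a small shift toward a weaker reading that may not exceed the scatter, and the step of a 1.5-fold higher number from compound 2 to compound 3 (0.19 log units; within the scatter) is the estimate. Compound 3 is expected at 2500 nM, within 900 nM to 7000 nM.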

Compound 3, half-maximal inhibitory concentration: 2720 nM
Compound 3: the middle estimate sits 1.1-fold (0.04 log units) below what was measured, and the stated range covers the measured number.
By their numbers in this assay, from the lowest: compounds 2, 1 and 3 (each within the scatter of the next).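

In this assay, chloro in place of (2-(dimethylamino)ethyl)amino on this aromatic carbon, opposite the ring nitrogen, gives a 1.7-fold higher number from compound 2 to compound 3 (0.23 log units; within the scatter), so on this read-out the two groups at this position cannot be told apart. The second change, phenyl in place of isopropyl on a saturated chain carbon bound to an oxygen on an aromatic ring, gives a 1.3-fold higher number from compound 1 to compound 3 (0.11 log units; within the scatter), and so it also stays inside the scatter when chloro is present. Nothing available here explains either result.

The compounds shown leave open whether another group on this aromatic carbon, such as a piperazine or a longer chain ending in a dimethylamino group, would move the number beyond the scatter. They also leave open whether replacing phenyl with isopropyl would matter when (2-(dimethylamino)ethyl)amino is present.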